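Ethoxycarbonyl in place of propyl on the amide carbonyl

A few compounds are considered here, and "the series" means these few. Any claim that something is new, unique, unknown or untested is made for them only; others in the source may bear on it.

Compound 1 `COc1cc(/C=C/C(=O)c2cccc(NC(=O)c3cc(Cl)cc(Cl)c3)c2)ccc1O`: 51%
Compound 2 `CCCC(=O)Nc1cccc(C(=O)/C=C/c2ccc(O)c(OC)c2)c1`: 57%

In a functional assay on HUVEC cells (Homo sapiens) for inhibition, tested at 5 ug/mL (on this read-out higher numbers stand for a stronger effect at the one concentration tested and lower numbers for a weaker effect), compound 2 and compound 1 lie within the scatter of each other, as a number 6 percentage points higher from compound 1 to compound 2 (within the scatter) shows. Compound 3 `CCOC(=O)C(=O)Nc1cccc(C(=O)/C=C/c2ccc(O)c(OC)c2)c1` differs from compound 2 by ethoxycarbonyl in place of propyl on a carbonyl carbon. Within the data shown here, the one measured step that bears on this, a number 6 percentage points higher from compound 1 to compound 2 (within the scatter), also exchanged the group on that carbonyl carbon and stayed within the scatter; no measured step covers ethoxycarbonyl itself. For compound 3 the expected step is a number 3 percentage points lower from compound 2 to compound 3 (within the scatter), nothing beyond the scatter. Compound 3 is estimated at 54%, between 34% and 74%.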

Compound 3, a percentage reported as inhibition, at one concentration (the size of the read-out at that concentration, not a potency): 45%
For compound 3 the middle estimate is 9 percentage points above the measured one, and the stated range covers the measured number.
By their numbers in this assay, from the lowest: compounds 3, 1 and 2 (each within the scatter of the next, the first and the last beyond it).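

In this assay the group on the carbonyl carbon next to the amide-type nitrogen now shows a step beyond the scatter: ethoxycarbonyl in place of propyl gives a number 12 percentage points lower from compound 2 to compound 3 (beyond the scatter), while ethoxycarbonyl in place of 3,5-dichlorophenyl gives a number 6 percentage points lower from compound 1 to compound 3 (within the scatter). So this position is not indifferent to every exchange, though only the change from propyl exceeds the scatter. Nothing measured here accounts for that step. Open, on these data alone, is whether the oxygen atoms of ethoxycarbonyl or its greater size carry the step, and how an amine, a carboxylic acid or a longer chain on this carbonyl carbon would compare with propyl.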